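The source may hold more compounds than are shown below. What is called first, only, known or untested is meant among the compounds shown, and "the series" means these compounds.

Compound 2 `Oc1ccc(Nc2nc(-c3cccc(F)c3)nc3ccc(F)cc23)cc1` carries a 4-hydroxyphenyl on a nitrogen on an aromatic ring of the shared core. In a functional assay on HT29-AK cells (Homo sapiens) for cytotoxicity, read by MTT assay, with a stated time of 48 h (a lower number here means a stronger inhibitor, a higher number a weaker inhibitor), compound 2 returns only a limit, > 50000 nM, and no number. Compound 1 `Fc1cccc(-c2nc(Nc3cccc(Cl)c3)c3cc(F)ccc3n2)c1`, its 3-chlorophenyl counterpart, stands in the same place: in this assay compound 1 also reaches only the limit, > 50000 nM. The step that the two limits leave unreadable from compound 1 to compound 2 therefore cannot be read, because both values sit at the limit of > 50000 nM in this assay, at which 2 of the 2 values shown sit. So compound 2 stands at the limit, with nothing in the series placing it any more precisely.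

Compound 3 `Oc1cccc(Nc2nc(-c3cccc(F)c3)nc3ccc(F)cc23)c1` is not yet measured. It differs from compound 2 in that (3-hydroxyphenyl in place of 4-hydroxyphenyl on a nitrogen on an aromatic ring). Among the measured compounds shown here, no measured step bears on this change; the only step, from compound 1 to compound 2, is unreadable, so it gives no size to carry over. On the evidence of compound 2 at > 50000 nM, compound 3 is expected to remain at or near the limit as well, with the step of a number no higher from compound 2 to compound 3 (the limit leaves the size open) expected to be none beyond the scatter. The estimate for compound 3 in this assay is 50000 nM, within a range of 15000 nM to 200000 nM.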

Compound 3, half-maximal inhibitory concentration: > 50000 nM
Compound 3 gave a limit, no number (the forecaster's own chance of this, stated with the estimate: 80%); the middle value lies on the limit itself.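

In this assay, among the compounds shown here, no step among compound 1, compound 2 and compound 3 can be read, because all three values are limits and not numbers: the limit of > 50000 nM in this assay, at which 3 of the 3 values shown sit. The compounds shown leave open how far each of the three lies from that limit, and whether 3-hydroxyphenyl and 4-hydroxyphenyl differ at all in this assay.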